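The source may hold more compounds than are shown below. What is called first, only, known or untested is meant among the compounds shown, and "the series" means these compounds.

Compound 1 `Nc1cc(N)c2nc(-c3ccccc3)c(NCc3ccc(Cl)c(Cl)c3)nc2c1`: 55000 nM
Compound 2 `COc1cc(CNc2nc3cc(N)cc(N)c3nc2-c2ccccc2)cc(OC)c1OC`: 14100 nM
Compound 3 `CCOC(=O)[C@H](CCC(=O)O)NC(=O)c1ccc(CNc2nc3cc(N)cc(N)c3nc2-c2ccccc2)cc1`: < 100000 nM

These three compounds share one core and differ only in the group carried on the saturated chain carbon bound to a nitrogen on an aromatic ring. In a functional assay on SF-268 cells (Homo sapiens) for inhibition, read by sulforhodamine B assay, with a stated time of 48 h (a higher number here means a weaker inhibitor of growth, a lower number a stronger inhibitor of growth), compound 1 gives 55000 nM, the highest of the two numbers measured, so among them it is the weaker inhibitor of growth. Compound 2 gives 14100 nM, a number that lies lower than that of compound 1 by more than the usual scatter. For compound 3 only a limit of the assay is known, < 100000 nM, not a number (the limit of < 100000 nM in this assay, at which 1 of the 3 values shown sits).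

Compound 4 `Nc1cc(N)c2nc(-c3ccccc3)c(NCc3ccc(F)cc3)nc2c1` has not yet been measured in this assay. It differs from compound 1 in one place: 4-fluorophenyl in place of 3,4-dichlorophenyl on a saturated chain carbon bound to a nitrogen on an aromatic ring. Going by the values given here, no two measured compounds differ from each other in a single place, so there is no measured step of this kind to lean on, and the expectation rests on compound 1 alone. The change is expected to amount to a 1.1-fold higher number from compound 1 to compound 4 (0.04 log units; within the scatter), which is no more than the scatter of repeated measurements. Compound 4 is therefore expected to give about 60000 nM in this assay, most likely between 20000 nM and 150000 nM.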

Compound 4, concentration for total growth inhibition: 7590 nM
Compound 4: the middle estimate sits 7.9-fold (0.90 log units) above what was measured; the whole stated range lies above it.
By their numbers in this assay, from the lowest: compounds 4 and 2 (each within the scatter of the next); then compound 1.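

Going by these compounds alone, the first comparison that changes a single place shows that the group on a saturated chain carbon bound to a nitrogen on an aromatic ring can shift the result: in this assay, 4-fluorophenyl in place of 3,4-dichlorophenyl gives a 7.2-fold lower number from compound 1 to compound 4 (0.86 log units; beyond the scatter). Since a lower number marks a stronger inhibitor of growth and this step lies beyond the usual scatter, compound 4 is the stronger inhibitor of this pair, so this position does not simply tolerate any halogen-bearing phenyl group equally. The step changes both the kind of halogen on the ring and how many there are, and nothing measured here explains its size.

The compounds shown leave open whether losing the chlorines or gaining the fluorine matters more, a question that 4-chlorophenyl or plain phenyl on the same carbon could help to answer. They also leave open how this position would respond to a group of a different kind, such as an amine or a longer chain.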